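Ester Exchange at a Shared Core: Expecting Compound 4

This account rests on a few compounds, and the source may have more. Where it says the series, first, only, none or still open, it means among the compounds named here.

Compound 1 `CC1=CCC2C(CC[C@@]2(C)O)C(C)(C)C1CC[C@@H]1[C@@]2(C)CCC(=O)C(C)(C)O[C@@H]2CC[C@]1(C)O`: > 50000 nM
Compound 2 `CC1=CC[C@H]2[C@H](CC[C@]2(C)O)C(C)(C)[C@@H]1CC[C@H]1[C@]2(C)CC[C@H](OC(=O)CCC(=O)O)C(C)(C)O[C@H]2CC[C@@]1(C)O`: 27900 nM
Compound 3 `CC1=CC[C@H]2[C@H](CC[C@]2(C)O)C(C)(C)[C@@H]1CC[C@H]1[C@]2(C)CC/C(=N/OCc3ccccc3)C(C)(C)O[C@H]2CC[C@@]1(C)O`: 38200 nM

All three were tested in a functional assay on MDA-MB-231 cells (Homo sapiens) for antiproliferative activity, read by MTT assay, with a stated time of 72 h; a lower number here means a stronger inhibitor, a higher number a weaker inhibitor. Compound 1 reaches only (the limit of > 50000 nM in this assay, at which 1 of the 3 values shown sits). Compound 2 gives 27900 nM and compound 3 gives 38200 nM; the gap between them lies within the scatter, so neither stands apart from the other. Compound 4 `CC1=CC[C@H]2[C@H](CC[C@]2(C)O)C(C)(C)[C@@H]1CC[C@H]1[C@]2(C)CC[C@H](OC(=O)c3ccccc3F)C(C)(C)O[C@H]2CC[C@@]1(C)O` is not yet measured. It differs from compound 2 in one place: 2-fluorophenyl in place of 2-carboxyethyl on a carbonyl carbon. For the measured compounds named here, no measured step of this kind exists here, so the direction is open; the expectation is a change of no more than the scatter, leaning if anything toward a somewhat stronger inhibitor. Compound 4 is expected at 20000 nM, between 7000 nM and 50000 nM. The step of a 1.4-fold lower number from compound 2 to compound 4 (0.14 log units; within the scatter) is thus estimated to stay near the scatter.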

Compound 4, half-maximal inhibitory concentration: 28700 nM
Compound 4: the middle estimate sits 1.4-fold (0.16 log units) below what was measured; the range from low to high includes it.
By their numbers in this assay, from the lowest: compounds 2, 4 and 3 (each within the scatter of the next). At a limit, above all of these: compound 1.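

At this position, 2-fluorophenyl in place of 2-carboxyethyl on a carbonyl carbon gives, in this assay, a 1.0-fold higher number from compound 2 to compound 4 (0.01 log units; within the scatter). This first step at the position shows that a carbon-only aromatic ring bearing fluorine and a chain bearing a hydrogen-bond donor can be exchanged here with no difference beyond the scatter. Nothing measured here speaks to a cause for this result. From the compounds shown here alone, whether an amine, a plain phenyl or a longer chain on this carbonyl carbon would give a number beyond the scatter stays open.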